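This account rests on a few compounds, and the source may have more. Where it says the series, first, only, none or still open, it means among the compounds named here.

The compounds measured so far, with their numbers in an assay on membranes from HEK293 cells for displacement of a labelled ligand from Type-2 angiotensin II receptor (Homo sapiens), read by radioligand binding; a lower number here means a stronger inhibitor, a higher number a weaker inhibitor:

compound 1, `CCCCOC(=O)NS(=O)(=O)c1ccc(CCC)cc1-c1ccc(Cn2c(-c3ccccc3)nc3ccccc32)cc1`, gives 590 nM
compound 2, `CCCCOC(=O)NS(=O)(=O)c1ccc(CCC)cc1-c1ccc(Cn2c(CC(C)C)nc3ccccc32)cc1`, gives 19 nM
compound 3, `CCCCOC(=O)NS(=O)(=O)c1ccc(CCC)cc1-c1ccc(Cn2c(C3CCC3)nc3ccccc32)cc1`, gives 12 nM

Compound 3 has the lowest number of the three. Its separation from compound 1 is large, a 49-fold lower number from compound 1 to compound 3 (1.69 log units; beyond the scatter), whereas the step of a 1.6-fold lower number from compound 2 to compound 3 (0.20 log units; within the scatter) is within the scatter, so compound 2 and compound 3 cannot be told apart on these numbers.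

Compound 4, `CCCCOC(=O)NS(=O)(=O)c1ccc(CCC)cc1-c1ccc(Cn2c(CC)nc3ccccc32)cc1`, differs from compound 3 in one place: ethyl in place of cyclobutyl on an aromatic carbon. Among the measured compounds shown here, two measured steps bear on this position. Both a 31-fold lower number from compound 1 to compound 2 (1.49 log units; beyond the scatter) and a 49-fold lower number from compound 1 to compound 3 (1.69 log units; beyond the scatter) show that replacing the phenyl with a small alkyl group lowers the number greatly, and a 1.6-fold lower number from compound 2 to compound 3 (0.20 log units; within the scatter) shows that exchanging one small alkyl group for another changes little. Ethyl is another small alkyl group, though shorter than either; no measured step shows what shrinking it this far does. The expected step of a 1.8-fold higher number from compound 3 to compound 4 (0.26 log units; within the scatter) is therefore small, at most slightly upward. Compound 4 is estimated at 22 nM, with a range from 8 nM to 65 nM.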

Compound 4, inhibition constant: 11 nM
For compound 4 the middle estimate is 2.0-fold (0.30 log units) above the measured one; the range from low to high includes it.
By their numbers in this assay, from the lowest: compounds 4, 3 and 2 (each within the scatter of the next); then compound 1.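

In this assay shrinking the group at this position to ethyl, with 2 heavy atoms and no ring, leaves no readable mark: a 1.1-fold lower number from compound 3 to compound 4 (0.04 log units; within the scatter) and a 1.7-fold lower number from compound 2 to compound 4 (0.24 log units; within the scatter) both lie within the scatter. The large gap stays with the loss of phenyl, a 54-fold lower number from compound 1 to compound 4 (1.73 log units; beyond the scatter), so on this aromatic carbon between two ring nitrogen atoms the ethyl, cyclobutyl and isobutyl groups cannot be told apart, and only phenyl stands away from them. No evidence is available to explain this pattern.

Going by these compounds, whether the smaller methyl or a longer chain such as hexyl would stay level with these three groups remains open. Also open, on these data alone, are what an amine or a carboxylic acid would do here, and whether a saturated six-membered ring such as cyclohexyl would behave like phenyl or like the smaller groups.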